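Trifluoromethyl replaces methoxy on a quinoline-free core description

The source may report more compounds than this note shows. Statements on the series, on what has been measured and on what is new or still open speak of the compounds shown alone.

Measured so far:
compound 1, `Cc1c(C(=O)Nc2c(F)cc(-c3cccc(F)c3)cc2F)nc2ccc(F)cc2c1C(=O)O`, 26.3% in a functional assay on Hep 3B2 cells (Homo sapiens) for antiproliferative activity, read by MTT assay, with a stated time of 24 h, tested at 11.11 ug/mL; a lower number here means a weaker effect, a higher number a stronger effect of the compound at the concentration tested
compound 2, `COc1ccc2nc(C(=O)Nc3c(F)cc(-c4cccc(F)c4)cc3F)c(C)c(C(=O)O)c2c1`, 2.34%

Compound 2 stands lowest of the two numbers; its nearest neighbour is compound 1, and the step of a number 24 percentage points lower from compound 1 to compound 2 (beyond the scatter) lies beyond the scatter. Compound 3, `Cc1c(C(=O)Nc2c(F)cc(-c3cccc(F)c3)cc2F)nc2ccc(C(F)(F)F)cc2c1C(=O)O`, is not yet measured. It differs from compound 2 in one place: trifluoromethyl in place of methoxy on an aromatic carbon. Among the measured compounds shown here, no measured step involves trifluoromethyl, so only the single step of a number 24 percentage points lower from compound 1 to compound 2 (beyond the scatter) gives any bearing, and it shows that the group at this place can move the read-out by a modest amount. Since methoxy is the group that leaves, the expectation for compound 3 is a rise back toward the level of compound 1, though with wide uncertainty. Compound 3 is therefore expected to give about 15%, between 0% and 35%, an expected step of a number 12.7 percentage points higher from compound 2 to compound 3 (beyond the scatter).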

Compound 3, a percentage reported as inhibition, at one concentration (the size of the read-out at that concentration, not a potency): 31.2%
Compound 3: middle estimate off by 16.2 percentage points, on the low side; the measured number falls inside the stated range.
By their numbers in this assay, from the lowest: compound 2; then compounds 1 and 3 (each within the scatter of the next).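

In this assay, the change to trifluoromethyl gives a number 28.9 percentage points higher from compound 2 to compound 3 (beyond the scatter), which shows that the low number of compound 2 does not hold for every larger group at this place. Trifluoromethyl in place of fluoro gives a number 4.9 percentage points higher from compound 1 to compound 3 (within the scatter), so fluoro and trifluoromethyl cannot be told apart here, and among these three compounds only the methoxy compound stands apart. No measurement shown explains why methoxy differs from the other two groups.

As far as these compounds go, it remains open whether the low number is specific to methoxy, or whether an ethoxy group, a hydroxyl group or an amine at this place would give a similar result. Each number also comes from a single concentration, so how the effects of these compounds compare at other concentrations remains open too.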